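A few compounds are considered here, and "the series" means these few. Any claim that something is new, unique, unknown or untested is made for them only; others in the source may bear on it.

Measured so far in an in vitro assay on BTI-TN-5B1-4 cells for inhibition of Amine oxidase [flavin-containing] B (Homo sapiens), tested at 100 uM; on this read-out lower numbers stand for less inhibition and higher numbers for more inhibition at the one concentration tested (going by the name of the read-out): compound 1 `Cc1ccc2c(=S)cc(-c3ccccc3)oc2c1` gives 40%; compound 2 `Cc1ccc2c(=S)cc(-c3ccc(F)cc3)oc2c1` gives 40%; compound 3 `COc1ccc2c(=S)cc(-c3ccc(F)cc3)oc2c1` gives 40%.

Compound 4 `COc1ccc2c(=S)cc(-c3ccccc3)oc2c1` remains to be measured in this assay. It differs from compound 3 by hydrogen in place of fluoro on an aromatic carbon. The same change has already been made once among the measured compounds, from compound 2 to compound 1, where it is described as hydrogen in place of fluoro on an aromatic carbon and gave no change at the digits printed from compound 2 to compound 1 (within the scatter). The cores of compound 3 and compound 2 differ by methoxy in place of methyl on an aromatic carbon, and the step there was no change at the digits printed from compound 2 to compound 3 (within the scatter). Because the earlier instance of this change gave no change at the digits printed from compound 2 to compound 1 (within the scatter), compound 4 is expected to show no change at the digits printed from compound 3 to compound 4 (within the scatter) beside it. Compound 4 is therefore estimated at 40% in this assay, with a range from 30% to 50%.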

Compound 4, a percentage reported as inhibition, at one concentration (the size of the read-out at that concentration, not a potency): 40%
Compound 4: middle estimate and measured number agree at the digits printed, within the range that was stated.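

The swap of hydrogen for fluoro carried over from one core to the other in this assay, where it gave no change at the digits printed from compound 3 to compound 4 (within the scatter): the same change on two cores in this assay, no change at the digits printed (within the scatter) from compound 2 to compound 1 and no change at the digits printed (within the scatter) from compound 3 to compound 4, 0 percentage points apart, within the scatter of two such steps. The swap of methoxy for methyl carried over in the same way in this assay, where it gave no change at the digits printed from compound 1 to compound 4 (within the scatter): the same change on two cores in this assay, no change at the digits printed (within the scatter) from compound 2 to compound 3 and no change at the digits printed (within the scatter) from compound 1 to compound 4, 0 percentage points apart, within the scatter of two such steps. Among these compounds, all four compounds stand level at one concentration, so this shows only that neither swap moved the read-out on these two cores; it does not show that a step of measurable size would carry over, and it gives no potency.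

The compounds shown leave open whether an amine, a carboxylic acid or a longer chain in place of fluoro on that aromatic carbon would move the read-out.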